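Trifluoromethyl for trifluoromethoxy at the assay limit

A few compounds are considered here, and "the series" means these few. Any claim that something is new, unique, unknown or untested is made for them only; others in the source may bear on it.

In a functional assay on NALM-6 cells (Homo sapiens) for cytotoxicity, with a stated time of 72 h (a lower number here means that less compound is needed, a higher number that more compound is needed for the effect), compound 1 `C=C[C@@](C)(/C=C/c1ccc(O)c(/C=C/C(=O)c2ccccc2)c1)CCC=C(C)C` gives a readable number, 4470 nM. Compound 2 `C=C[C@@](C)(/C=C/c1ccc(Nc2ccccc2)cc1)CCC=C(C)C` gives only a limit, > 43400 nM. Compound 3 `C=C[C@@](C)(/C=C/c1ccc(Nc2cccc(OC(F)(F)F)c2)cc1)CCC=C(C)C` also gives only a limit, > 43400 nM, so its standing has no exact number. Compound 4 `C=C[C@@](C)(/C=C/c1ccc(Nc2cccc(C(F)(F)F)c2)cc1)CCC=C(C)C` differs from it by trifluoromethyl in place of trifluoromethoxy on an aromatic carbon, with trifluoromethyl in place of trifluoromethoxy on an aromatic carbon. For the measured compounds named here, the one measured step that bears on this is a step that the two limits leave unreadable from compound 2 to compound 3, and it offers no size to carry over, since both compounds sit at the limit of > 43400 nM in this assay, at which 2 of the 3 values shown sit. No step beyond the scatter is therefore expected in this assay, and the expected change is a step that the limit leaves unreadable from compound 3 to compound 4. Compound 4 is estimated at 45000 nM, with an expected range from 20000 nM to 70000 nM.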

Compound 4, half-maximal effective concentration: > 43400 nM
Compound 4: a limit, no number; the forecaster's own chance of this, stated with the estimate: 80%; the middle value lies beyond the limit too.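

Compound 2, compound 3 and compound 4 all stop at a limit, so no step among them can be read: the limit of > 43400 nM in this assay, at which 3 of the 4 values shown sit.

The compounds shown leave open how hydrogen, trifluoromethoxy and trifluoromethyl on this aromatic carbon compare in this assay.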